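This account rests on a few compounds, and the source may have more. Where it says the series, first, only, none or still open, it means among the compounds named here.

Measured so far in an ADME assay on microsomes from liver (Rattus norvegicus) for metabolic stability, with a stated time of 10 min; a lower number here means that less of the compound is left, a higher number that more of the compound is left:
compound 1 `CC(C)S(=O)(=O)NC(=O)c1ccc(Nc2nc(NC3(c4ccc(Cl)cc4)CC3)nc(OCC(F)(F)F)n2)cc1`: 96%
compound 2 `CC(C)(C)OC(=O)NCCS(=O)(=O)NC(=O)c1ccc(Nc2nc(NC3(c4ccc(Cl)cc4)CC3)nc(OCC(F)(F)F)n2)cc1`: 93%
compound 3 `O=C(NS(=O)(=O)CCNC(=O)C1CC1)c1ccc(Nc2nc(NC3(c4ccc(Cl)cc4)CC3)nc(OCC(F)(F)F)n2)cc1`: "not active" (no number reported), reported without a number

Compound 1 stands highest of the two numbers in this assay. Its nearest neighbour is compound 2, and the step of a number 3 percentage points lower from compound 1 to compound 2 (within the scatter) lies within the scatter, so the two cannot be ordered. Compound 3 contributes no number and is set aside.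

The compound in question is compound 4 `CC(C)(C)CNCCS(=O)(=O)NC(=O)c1ccc(Nc2nc(NC3(c4ccc(Cl)cc4)CC3)nc(OCC(F)(F)F)n2)cc1`. It differs from compound 1 in one place: 2-(neopentylamino)ethyl in place of isopropyl on a sulfonyl sulfur.

Among the measured compounds shown here, only one measured step bears on this change. From compound 1 to compound 2 the isopropyl on the sulfonyl sulfur was likewise exchanged for a two-carbon chain ending in a nitrogen, there as 2-((tert-butoxycarbonyl)amino)ethyl, and that step a number 3 percentage points lower from compound 1 to compound 2 (within the scatter) stayed within the scatter. For the measured compounds named here, no measured pair shows the neopentylamino end itself, so nothing in the data speaks for a large shift in either direction.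

For compound 4 the expectation is therefore a number close to compound 1, with the step of a number 6 percentage points lower from compound 1 to compound 4 (within the scatter) expected to stay within the scatter. Compound 4 is estimated at 90%, with a range from 75% to 99%.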

Compound 4, percent of the compound remaining: 90%
The estimate for compound 4 equals the measured number at the digits printed, and the stated range covers the measured number.
By their numbers in this assay, from the lowest: compounds 4, 2 and 1 (each within the scatter of the next).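

In this assay the exchange of isopropyl for 2-(neopentylamino)ethyl on a sulfonyl sulfur gives a number 6 percentage points lower from compound 1 to compound 4 (within the scatter) and so no readable shift, which extends the tolerance seen with the tert-butoxycarbonyl-capped chain to a chain whose nitrogen carries an alkyl group and keeps its hydrogen-bond donor. The end of the chain also makes no readable difference in this pair, since neopentyl in place of tert-butoxycarbonyl on an amine nitrogen gives a number 3 percentage points lower from compound 2 to compound 4 (within the scatter) and the two compounds cannot be ordered, so the tert-butoxycarbonyl group is not needed for a reading in this range. No data at hand explain why these readings stay so close.

With compound 3 reported without a number, the series gives no reading for a chain ending in an amide, so only the carbamate and the neopentyl-substituted amine define the end of the chain in this assay. Still open, as far as these compounds go, is whether a free primary amine, a carboxylic acid or a longer chain on the sulfonyl sulfur would stay within the same narrow band of readings.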